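Cyclic nucleotide series: amino replacing benzylsulfanyl on the core

The source may hold more compounds than are shown below. What is called first, only, known or untested is meant among the compounds shown, and "the series" means these compounds.

Measured so far:
- compound 1, `Nc1ncnc2c1nc(S)n2[C@@H]1O[C@@H]2COP(=O)(O)O[C@H]2[C@H]1O`: no result reported in a functional assay on the whole organism for activation, with Mus musculus as the target, with stated times of 14 days and 2 h, at a dose of 15 mg/kg by the intravenous route; on this read-out higher numbers stand for a stronger effect at the one dose given and lower numbers for a weaker effect
- compound 2, `Nc1ncnc2c1nc(SCc1ccccc1)n2[C@@H]1O[C@@H]2COP(=O)(O)O[C@H]2[C@H]1O`: 183%

Within the data shown here, compound 2 is the only member with a number: in this assay compound 2 gives 183%. Compound 1 carries the same core with a thiol in place of the benzylsulfanyl group and has no reported result, so it gives no reference for how the group on the five-membered aromatic ring affects the read-out. Among the measured compounds shown here, no step between two measured compounds is available.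

Compound 3, `Nc1ncnc2c1nc(N)n2[C@@H]1O[C@@H]2COP(=O)(O)O[C@H]2[C@H]1O`, differs from compound 2 by amino in place of benzylsulfanyl on an aromatic carbon. The change removes the benzylsulfanyl group, with its six-membered aromatic ring of carbon only, and installs an amino group, a single nitrogen that adds one hydrogen-bond donor, on the aromatic carbon between two ring nitrogen atoms of the core.

For the measured compounds named here, with no measured step to guide the direction, the expectation for compound 3 rests only on the value of compound 2 and the size of the change. The step is expected to be a decrease beyond the scatter, a number 63 percentage points lower from compound 2 to compound 3 (beyond the scatter), with low confidence in its size. Compound 3 is therefore estimated at 120%, within a range of 50% to 200%.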

Compound 3, a percentage reported as activity, at one dose (the size of the read-out at that dose, not a potency): 663%
For compound 3 the middle estimate is 543 percentage points below the measured one; measured number outside the range, above it.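

In this assay, among these compounds, the exchange of benzylsulfanyl for amino gives a number 480 percentage points higher from compound 2 to compound 3 (beyond the scatter) and is the only step that can be read at this position. On this pair, the six-membered aromatic ring of carbon only is not required for a strong read-out at the one dose given, and the aromatic carbon between two ring nitrogen atoms can carry the much smaller amino group with a far higher value. Nothing shown accounts for the size of this step.

Compound 1, with its thiol, has no result, so this single pair cannot separate a gain tied to the amino group itself from one that follows the loss of benzylsulfanyl. Open questions remain for other groups on the same carbon: benzylamino would keep the ring while placing nitrogen on the core, and methylsulfanyl would keep the sulfur without the ring, so each would help to separate these two readings.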